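A few compounds are considered here, and "the series" means these few. Any claim that something is new, unique, unknown or untested is made for them only; others in the source may bear on it.

Compound 1, `CC(=O)Nc1ncc(-c2ccccc2)c(C(C)(C)C)n1`: 29%
Compound 2, `Cc1ncnnc1-c1ccccc1`: < 5%

Among the compounds with values here, in a functional assay on the whole organism for inhibition, with Rattus norvegicus as the target, with stated times of 1 h and 3.5 h, at a dose of 100 mg/kg by the oral route (a higher number here means more inhibition at the dose given (going by the name of the read-out), a lower number less inhibition), compound 1 gives 29%, the only plain number among the two results. Compound 2 is reported only as a limit of the assay: in this assay compound 2 gives < 5%. Of the two values shown, compound 2 thus stands at the lower edge of what this assay reports, (the limit of < 5% in this assay, at which 1 of the 2 values shown sits). Within the data shown here, no pair of measured compounds differs in one place, so no measured step is available to guide what a single change might do.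

Compound 3, `Cc1nc(-c2ccccc2)nnc1-c1ccccc1`, differs from compound 2 by phenyl in place of hydrogen on an aromatic carbon. Among the measured compounds shown here, with no measured step to lean on, the expectation rests on the starting point alone. Since compound 2 sits at the limit, any movement can only be upward, and it is expected to be small, at most a little beyond the scatter: the step of a number at least 7 percentage points higher from compound 2 to compound 3 (that floor lies within the scatter) is the estimate here. Compound 3 is therefore expected to give 12% in this assay, with a range from 0% to 30%.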

Compound 3, a percentage reported as inhibition, in the whole organism at one dose (the size of the read-out at that dose, not a potency): < 5%
Compound 3 was reported as a limit; the forecaster's own chance of this, stated with the estimate: 40%; at least 7 percentage points between middle value and limit.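

In this assay, compound 2 and compound 3 are both reported only as limits, so no step can be read for phenyl in place of hydrogen on an aromatic carbon: the limit of < 5% in this assay, at which 2 of the 3 values shown sit.

The compounds shown leave open whether this change alters inhibition at all, as any difference between compound 2 and compound 3 remains unresolved.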